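Phenyl for Methyl on the Tetrazole Nitrogen

This account rests on a few compounds, and the source may have more. Where it says the series, first, only, none or still open, it means among the compounds named here.

In a functional assay on C6 cells (Rattus norvegicus) for cytotoxicity, read by MTT assay, with a stated time of 24 h, tested at 100 ug/mL (on this read-out higher numbers stand for a weaker effect at the one concentration tested and lower numbers for a stronger effect), compound 1 `O=C(CSc1nnnn1-c1ccccc1)N/N=c1/scc(-c2ccc(F)cc2)n1-c1ccccc1` gives 35.8%. Compound 2 `Cn1nnnc1SCC(=O)N/N=c1/scc(-c2ccc(C#N)cc2)n1-c1ccccc1` gives 30.9% in this assay, and the two numbers lie within the scatter of each other, so the pair shows no difference beyond it. Compound 3 `N#Cc1ccc(-c2cs/c(=N/NC(=O)CSc3nnnn3-c3ccccc3)n2-c2ccccc2)cc1` differs from compound 2 by phenyl in place of methyl on an aromatic nitrogen. Since compound 1 already carries the phenyl on that nitrogen and its value 35.8% sits within the scatter of compound 2, the expected step of a number 3.1 percentage points higher from compound 2 to compound 3 (within the scatter) is small, with no direction beyond the scatter. Compound 3 is therefore estimated at 34%, between 22% and 46%.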

Compound 3, a percentage reported as activity, at one concentration (the size of the read-out at that concentration, not a potency): 59.8%
The estimate for compound 3 lay 25.8 percentage points below the measured number; the measured number lies above the stated range.
By their numbers in this assay, from the lowest: compounds 2 and 1 (each within the scatter of the next); then compound 3.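

In this assay the substituent on the tetrazole nitrogen proves to matter: with cyano kept, phenyl in place of methyl on that aromatic nitrogen gives a number 28.9 percentage points higher from compound 2 to compound 3 (beyond the scatter), a weaker effect at the one concentration tested. With phenyl kept on that nitrogen, cyano in place of fluoro on an aromatic carbon gives a number 24 percentage points higher from compound 1 to compound 3 (beyond the scatter), so the change on the aromatic carbon counts as well. Nothing available here explains either step. The compounds shown leave open how an ethyl or benzyl group on that nitrogen would read, and whether a free amine there would behave like methyl or like phenyl.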